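The source may report more compounds than this note shows. Statements on the series, on what has been measured and on what is new or still open speak of the compounds shown alone.

Measured so far:
compound 1, `O=C(O)c1ccc2noc(-c3ccc(N4CCCCC4)cc3)c2c1`: 1790 nM
compound 2, `O=C(O)c1ccc2noc(-c3ccc(Oc4ncc(Cl)cc4Cl)cc3)c2c1`: 2250 nM

For the measured compounds named here, in an assay for inhibition of inositol hexakisphosphate kinase 3 (Homo sapiens), read by colorimetric assay, coupled enzyme assay and malachite green, with a stated time of 120 min, in the presence of a further agent that is not named here (a higher number here means a weaker inhibitor, a lower number a stronger inhibitor), compound 2 gives 2250 nM, the higher of the two numbers, yet the only measured step, a 1.3-fold higher number from compound 1 to compound 2 (0.10 log units; within the scatter), lies within the scatter, so the two compounds are not separated. Compound 3, `CC(C)C(=O)Nc1ccc(-c2onc3ccc(C(=O)O)cc23)cc1`, differs from compound 2 by (isopropylcarbonyl)amino in place of (3,5-dichloropyridin-2-yl)oxy on an aromatic carbon. Going by the values given here, no measured step involves an amide, and the one step that does exchange this para group, a 1.3-fold higher number from compound 1 to compound 2 (0.10 log units; within the scatter), was small, so the expected change in this assay is none beyond the scatter. Compound 3 is therefore estimated at 2000 nM, ranging from 700 nM to 6000 nM, an expected step of a 1.1-fold lower number from compound 2 to compound 3 (0.05 log units; within the scatter).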

Compound 3, half-maximal inhibitory concentration: 210 nM
Compound 3: the middle estimate sits 9.5-fold (0.98 log units) above what was measured, outside the stated range (below it).
By their numbers in this assay, from the lowest: compound 3; then compounds 1 and 2 (each within the scatter of the next).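

The group at this position does matter in this assay: the change gives an 11-fold lower number from compound 2 to compound 3 (1.03 log units; beyond the scatter) and also an 8.5-fold lower number from compound 1 to compound 3 (0.93 log units; beyond the scatter) so two quite different starting groups both lose out to the (isopropylcarbonyl)amino group. The earlier exchange between those two groups had hidden this sensitivity. Nothing measured here explains the gain.

Compared with the group it replaces in compound 2, the new group brings a hydrogen-bond donor and has no ring, and either difference might matter. Going by these compounds, whether an acetylamino group or a longer chain on the carbonyl would do as well remains open.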